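Replacing Furan with Formylthiophene: An Expected Outcome

The compounds below may be only part of what the source reports. "The series", "measured", "known", "first", "only" and "open" are said of these compounds alone.

Measured compounds in a functional assay on MV4-11 cells (Homo sapiens) for inhibition, read by resazurin assay, with a stated time of 72 h; on this read-out higher numbers stand for weaker inhibition of growth and lower numbers for stronger inhibition of growth:
compound 1, `O=C1NCCC12CCN(c1c(Cl)cncc1-c1ccoc1)CC2`, 750 nM
compound 2, `O=Cc1ccc(-c2cncc(Cl)c2N2CCC3(CCNC3=O)CC2)o1`, 5190 nM
compound 3, `O=Cc1ccc(-c2cncc(Cl)c2N2CCC3(CCNC3=O)CC2)s1`, 750 nM

Compound 1 stands level with compound 3 at the digits shown, the two together the lowest of the three numbers; compound 2 lies furthest from it, a 6.9-fold higher number from compound 1 to compound 2 (0.84 log units; beyond the scatter). Compound 4, `O=Cc1cscc1-c1cncc(Cl)c1N1CCC2(CCNC2=O)CC1`, differs from compound 1 by 4-formylthiophen-3-yl in place of furan-3-yl on an aromatic carbon. Going by the values given here, two measured steps bear on this change: no change at the digits printed from compound 1 to compound 3 (within the scatter), where a formylthiophene likewise replaced the furan, and a 6.9-fold lower number from compound 2 to compound 3 (0.84 log units; beyond the scatter), where thiophene replaced furan. Among the compounds with values here, no measured step covers the 4-formylthiophen-3-yl group itself. Compound 4 is therefore expected to sit close to compound 1, with a 1.2-fold higher number from compound 1 to compound 4 (0.08 log units; within the scatter) inside the scatter. The estimated value for compound 4 is 900 nM, in the range 350 nM to 2500 nM.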

Compound 4, concentration for 50% growth inhibition: 27100 nM
Beside the measured number, compound 4's estimate is 30-fold (1.48 log units) below it; measured number above the stated range.
By their numbers in this assay, from the lowest: compounds 1 and 3 (each within the scatter of the next); then compound 2; then compound 4.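

Moving to 4-formylthiophen-3-yl from 5-formylthiophen-2-yl gives a 36-fold higher number from compound 3 to compound 4 (1.56 log units; beyond the scatter), so at this aromatic carbon a formylthiophene does not carry a fixed effect: where the formyl group stands on the thiophene matters greatly. Against furan-3-yl the change gives a 36-fold higher number from compound 1 to compound 4 (1.56 log units; beyond the scatter), and even against 5-formylfuran-2-yl it gives a 5.2-fold higher number from compound 2 to compound 4 (0.72 log units; beyond the scatter). Going by these compounds, whether a hydroxymethyl group or a nitrile in place of the formyl group of 4-formylthiophen-3-yl would restore growth inhibition stays open. No measurement at hand explains the large gap between the two formylthiophene isomers.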